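Swapping the aryl on the ring nitrogen of a pyridone amide

The source may hold more compounds than are shown below. What is called first, only, known or untested is meant among the compounds shown, and "the series" means these compounds.

Measured compounds:
Compound 1, `CNC(=O)c1cc(Oc2ccc(NC(=O)c3cc4cccnc4n(-c4ccc(Cl)cc4)c3=O)cc2)ccn1`, "not determined" (no result reported).
Compound 2, `CNC(=O)c1cc(Oc2ccc(NC(=O)c3cc4cccnc4n(-c4ccc(Br)cc4)c3=O)cc2)ccn1`, 3710 nM.

Compound 1 carries a 4-chlorophenyl on the aromatic nitrogen of the shared core, but in a functional assay on NCI-H460 cells (Homo sapiens) for antiproliferative activity, read by MTT assay, with a stated time of 72 h (a lower number here means a stronger inhibitor, a higher number a weaker inhibitor), compound 1 has "not determined" (no result reported). Compound 2 carries a 4-bromophenyl at the same position, and in this assay compound 2 gives 3710 nM. For the measured compounds named here, this is the only number in the set, so compound 2 stands alone; nothing can be said about how it ranks against compound 1.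

Compound 3, `CNC(=O)c1cc(Oc2ccc(NC(=O)c3cc4cccnc4n(-c4ccc(C(F)(F)F)cc4Cl)c3=O)cc2)ccn1`, is the next step. The change is 2-chloro-4-(trifluoromethyl)phenyl in place of 4-bromophenyl on an aromatic nitrogen, in words: 2-chloro-4-(trifluoromethyl)phenyl in place of 4-bromophenyl on an aromatic nitrogen. Going by the values given here, no measured pair in this set shows what such a change does here, so the expectation rests on compound 2 alone. The step from compound 2 to compound 3 is expected to be modest, a 1.5-fold lower number from compound 2 to compound 3 (0.17 log units; within the scatter), most likely within or just beyond the scatter and, if anything, toward a stronger inhibitor. Compound 3 is therefore estimated at 2500 nM in this assay, with a range from 600 nM to 9000 nM.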

Compound 3, half-maximal inhibitory concentration: 2110 nM
The estimate for compound 3 lay 1.2-fold (0.07 log units) above the measured number; measured number inside the range.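

For the compounds shown here, the swap of 4-bromophenyl for 2-chloro-4-(trifluoromethyl)phenyl on the aromatic nitrogen gives the first comparison at this position in this assay, as compound 1 offered no number to compare: the result is a 1.8-fold lower number from compound 2 to compound 3 (0.25 log units; within the scatter), so the two compounds cannot be told apart in this assay. This position therefore carries a larger aryl with two substituents in place of a single bromine, with no change that can be read beyond the scatter, though this rests on one pair only. The data at hand offer no measurement that would explain this outcome.

Any step involving compound 1 cannot be read, so the 4-chlorophenyl group remains unplaced against the 4-bromophenyl group, and the separate contributions of the chlorine and the trifluoromethyl group stay unresolved. Also open, from the compounds shown here alone, is whether this nitrogen would respond differently to a substituent of another kind, such as a phenyl carrying an amine or a carboxylic acid, or a simple methyl or longer alkyl chain in place of the aryl ring.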